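The source may hold more compounds than are shown below. What is called first, only, known or untested is meant among the compounds shown, and "the series" means these compounds.

Measured compounds:
- compound 1, `O=C(/C=C/c1ccc(Oc2cc(=O)oc3ccccc23)cc1)/C=C/c1ccccn1`: 25200 nM
- compound 2, `O=C(/C=C/c1ccc(Oc2cc(=O)oc3ccccc23)cc1)/C=C/c1cccnc1`: 17400 nM

In a functional assay on SGC-7901 cells (Homo sapiens) for antiproliferative activity, read by MTT assay, with a stated time of 48 h (on this read-out higher numbers stand for weaker inhibition and lower numbers for stronger inhibition), compound 2 gives the lower of these two numbers, but the step of a 1.4-fold lower number from compound 1 to compound 2 (0.16 log units; within the scatter) lies within the scatter, so the two compounds cannot really be told apart on this read-out. Among the measured compounds shown here, that single step is the only comparison available, and it swaps one pyridine attachment for another while keeping the nitrogen.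

Compound 3, `O=C(/C=C/c1ccc(Cl)cc1)/C=C/c1ccc(Oc2cc(=O)oc3ccccc23)cc1`, differs from compound 2 in one place: 4-chlorophenyl in place of pyridin-3-yl on a double-bonded chain carbon bound to a double-bonded chain carbon. For the measured compounds named here, this change removes the nitrogen-bearing ring altogether and brings in a chlorine-bearing carbon ring, a change that no measured step covers. Going by the values given here, the only related step, between compound 1 and compound 2, was within the scatter, which gives no basis to expect a large shift in either direction, but it also does not test the loss of the nitrogen, so the uncertainty is wide.

The expected step is a 1.5-fold lower number from compound 2 to compound 3 (0.16 log units; within the scatter), a modest change not clearly beyond the scatter. Compound 3 is therefore estimated at 12000 nM, with a range from 4000 nM to 35000 nM.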

Compound 3, half-maximal inhibitory concentration: 48300 nM
For compound 3 the middle estimate is 4.0-fold (0.60 log units) below the measured one, and the stated range ends below it.
By their numbers in this assay, from the lowest: compounds 2, 1 and 3 (each within the scatter of the next, the first and the last beyond it).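

In this assay, putting 4-chlorophenyl in place of pyridin-3-yl gives a 2.8-fold higher number from compound 2 to compound 3 (0.44 log units; beyond the scatter), so this place on the chain does respond to the ring it carries, which the swap between the two pyridine attachments could not show. The result is less clear-cut against the other pyridine: 4-chlorophenyl in place of pyridin-2-yl gives a 1.9-fold higher number from compound 1 to compound 3 (0.28 log units; within the scatter), so compound 3 can be told apart from compound 2 but not from compound 1. This change removes the ring nitrogen and adds a chlorine in a single step, and nothing available shows what lies behind the difference.

The compounds shown therefore leave open whether the ring nitrogen or the chlorine matters more, and a plain phenyl ring at this place would help to separate the two. Going by these compounds, it also remains open how a ring carrying an amine or a carboxylic acid would read here, and whether any ring at this place can give much stronger inhibition than compound 2.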